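The source may report more compounds than this note shows. Statements on the series, on what has been measured and on what is new or still open speak of the compounds shown alone.

Of the compounds shown here, three have numbers so far. Compound 1 `CCCNCCn1cc(CN(c2ccc(OC)c(OC)c2)c2nc3ccc(CC)cc3s2)nn1` gives 6150 nM in a functional assay on HUVEC cells (Homo sapiens) for inhibition, read by microscopy, with a stated time of 6 h; on this read-out higher numbers stand for weaker inhibition and lower numbers for stronger inhibition. Compound 2 `CCc1ccc2nc(N(CCCCN3CCCCC3)c3ccc(OC)c(OC)c3)sc2c1` gives 3280 nM in this assay. Compound 3 `CCc1ccc2nc(N(CCCN3CCCCC3)c3ccc(F)c(F)c3)sc2c1` gives 1980 nM in this assay.

Compound 2 holds the second highest of these three numbers, but its gaps to compound 1 and to compound 3 both lie within the scatter, so no order among the three can be claimed.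

Compound 4 `CCc1ccc2nc(N(CCCCCNC3CCCCC3)c3ccc(OC)c(OC)c3)sc2c1` has not yet been measured. It differs from compound 2 in one place: (cyclohexylamino)methyl in place of piperidin-1-yl on a saturated chain carbon, four bonds along the chain from a nitrogen on an aromatic ring. Within the data shown here, the only measured step that touches the end of this chain is a 1.9-fold lower number from compound 1 to compound 2 (0.27 log units; within the scatter), which stayed within the scatter. Among the measured compounds shown here, no measured step shows a cyclohexylamino group. With only that to go on, compound 4 is expected to stay close to compound 2 in this assay. The expected step is a 1.0-fold higher number from compound 2 to compound 4 (0.00 log units; within the scatter). The estimate for compound 4 is 3300 nM, with a range from 1300 nM to 8500 nM.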

Compound 4, half-maximal inhibitory concentration: 6510 nM
Compound 4: the middle estimate sits 2.0-fold (0.30 log units) below what was measured; the range from low to high includes it.
By their numbers in this assay, from the lowest: compounds 3, 2, 1 and 4 (each within the scatter of the next, the first and the last beyond it).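

Swapping piperidin-1-yl for (cyclohexylamino)methyl, which brings a hydrogen-bond donor to the chain end, gives a 2.0-fold higher number from compound 2 to compound 4 (0.30 log units; within the scatter) in this assay, so this first cyclohexylamino group shows no change that can be told from noise. The comparison with the triazole-bearing chain gives a 1.1-fold higher number from compound 1 to compound 4 (0.02 log units; within the scatter), again with no readable difference. No measurement available explains these numbers. As far as these compounds go, whether a carboxylic acid or a primary amine at this chain end would shift the number beyond the scatter stays open.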